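Working notes: fluoro in place of methoxy

The compounds below may be only part of what the source reports. "The series", "measured", "known", "first", "only" and "open" are said of these compounds alone.

Measured so far in a functional assay on MCF7 cells (Homo sapiens) for antiproliferative activity, read by sulforhodamine B assay, with a stated time of 48 h; a higher number here means a weaker inhibitor, a lower number a stronger inhibitor:
- compound 1 `CCN1CCN(c2ccc(S(=O)(=O)Oc3cccc(F)c3)cc2)C1=O` gives > 100000 nM (a limit of the assay, not a number)
- compound 2 `CCCN1CCN(c2ccc(S(=O)(=O)Oc3cccc(OC)c3)cc2)C1=O` gives 6300 nM

In this assay, among the measured compounds shown here, compound 2 gives 6300 nM, the only actual number so far.

The next compound to be measured is compound 3 `CCCN1CCN(c2ccc(S(=O)(=O)Oc3cccc(F)c3)cc2)C1=O`. Relative to compound 2, it carries fluoro in place of methoxy on an aromatic carbon, meta to a large group (fluoro in place of methoxy on an aromatic carbon). This turns the 3-methoxyphenyl group into 3-fluorophenyl, while the propyl chain stays.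

For the measured compounds named here, no measured pair isolates this change. Going by the values given here, the only other evidence is that the 3-fluorophenyl group also occurs with ethyl in place of propyl in compound 1, which stands at the limit > 100000 nM.

On that basis, a moderate step toward weaker inhibition in this assay is expected, beyond the usual scatter, though its size is poorly defined. The estimated change is a 4.8-fold higher number from compound 2 to compound 3 (0.68 log units; beyond the scatter). For compound 3 the expected value is 30000 nM, with an estimated range of 8000 nM to 100000 nM.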

Compound 3, half-maximal inhibitory concentration: 24000 nM
Compound 3: middle estimate off by 1.3-fold (0.10 log units), on the high side, and the stated range covers the measured number.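

In this assay, among the compounds shown here, the only pair isolating this position gives a 3.8-fold higher number from compound 2 to compound 3 (0.58 log units; beyond the scatter), so with the propyl chain held constant, fluoro in place of methoxy on the aromatic carbon weakens inhibition. For the compounds shown here, the chain also counts: with the 3-fluorophenyl group kept, methyl in place of hydrogen on a saturated chain carbon gives an at least 4.1-fold lower number from compound 1 to compound 3 (0.61 log units; beyond the scatter), a contribution that the earlier compounds could not separate from the change on the aromatic ring. Compound 1 gives > 100000 nM, which is a limit of the assay and not a number, so the step involving it is only a bound and its full size stays unknown: the limit of > 100000 nM in this assay, at which 1 of the 3 values shown sits.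

The 3-methoxyphenyl group appears here only with the propyl chain, which leaves open whether methoxy would give a similar advantage with an ethyl chain and whether the two changes act independently. Also open, going by these compounds, is how this assay responds to a hydroxy group, an amine or a nitrile at this ring position, or to a butyl chain in place of propyl.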